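The source may hold more compounds than are shown below. What is called first, only, known or untested is meant among the compounds shown, and "the series" means these compounds.

Compound 1 `COc1cc(NC(=O)Nc2cccc(C)c2)ccc1-c1cnco1`: 2300 nM
Compound 2 `COc1cc(Nc2ncc(-c3ccccc3)o2)ccc1-c1cocn1`: > 10000 nM

Only compound 1 gives a number in a functional assay on CCRF-CEM cells (Homo sapiens) for inhibition; on this read-out higher numbers stand for weaker inhibition and lower numbers for stronger inhibition. For compound 2 the result in this assay is a limit of the assay, > 10000 nM, not a measured number. Compound 3 `COc1cc(Nc2ncc(-c3ccccc3N(C)C(=O)CO)o2)ccc1-c1cocn1` has not yet been measured. It differs from compound 2 by ((hydroxymethyl)carbonyl)(methyl)amino in place of hydrogen on an aromatic carbon. For the measured compounds named here, no measured pair shows what such a change does here, so its direction is open; a step no larger than the usual scatter is expected, and the result may again be a limit. The expected step is an at least 1.2-fold lower number from compound 2 to compound 3 (0.09 log units; that floor lies within the scatter). Compound 3 is thus estimated at 8000 nM, between 2000 nM and 30000 nM.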

Compound 3, half-maximal inhibitory concentration: 3700 nM
The estimate for compound 3 lay 2.2-fold (0.33 log units) above the measured number; measured number inside the range.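

In this assay, putting ((hydroxymethyl)carbonyl)(methyl)amino in place of hydrogen on an aromatic carbon, ortho to a large group, gives an at least 2.7-fold lower number from compound 2 to compound 3 (0.43 log units; beyond the scatter). This position therefore takes a substituent, and here the change brings inhibition to a measurable level. The true size of the step remains unknown because compound 2 has only a limit of the assay: the limit of > 10000 nM in this assay, at which 1 of the 3 values shown sits.

One compound cannot show which part of the new group matters. Nor do the compounds shown tell whether a simple amine, a carboxylic acid or a longer chain here would give a similar result.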